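The source may report more compounds than this note shows. Statements on the series, on what has been measured and on what is new or still open speak of the compounds shown alone.

In an assay for positive allosteric modulation of metabotropic glutamate receptor 3 (Rattus norvegicus) (a higher number here means that more compound is needed for the effect, a lower number that less compound is needed), compound 1 `Cc1c(OC[C@@H](C)COc2cc(C(=O)O)ccc2F)ccc(C(=O)CC(C)(C)C)c1O` gives 3950 nM and compound 2 `Cc1c(OC[C@@H](C)COc2ccc(Cl)c(C(=O)O)c2)ccc(C(=O)CC(C)(C)C)c1O` gives 2200 nM; the step of a 1.8-fold lower number from compound 1 to compound 2 (0.25 log units; within the scatter) lies within the scatter, so compound 2 stands level with compound 1 on the two numbers available. Compound 3 `Cc1c(OC[C@@H](C)COc2ccc(C(=O)O)cc2Cl)ccc(C(=O)CC(C)(C)C)c1O` differs from compound 2 by 4-carboxy-2-chlorophenyl in place of 3-carboxy-4-chlorophenyl on an oxygen on a saturated carbon. Going by the values given here, the only step that bears on such a rearrangement of the same atoms is a 1.8-fold lower number from compound 1 to compound 2 (0.25 log units; within the scatter), which changed little. No step beyond the scatter in this assay is therefore expected. Compound 3 is expected to give 3000 nM, with a range of 1000 nM to 9000 nM. That amounts to an estimated step of a 1.4-fold higher number from compound 2 to compound 3 (0.13 log units; within the scatter).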

Compound 3, half-maximal effective concentration: 1650 nM
Compound 3: the middle estimate sits 1.8-fold (0.26 log units) above what was measured, within the range that was stated.
By their numbers in this assay, from the lowest: compounds 3, 2 and 1 (each within the scatter of the next, the first and the last beyond it).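

In this assay, the 4-carboxy-2-chlorophenyl group leaves compound 3 level with compound 2, with a 1.3-fold lower number from compound 2 to compound 3 (0.12 log units; within the scatter). Going by these compounds alone, the same group, placed against the 5-carboxy-2-fluorophenyl group, gives the first step beyond the scatter at this position, though a modest one, with a 2.4-fold lower number from compound 1 to compound 3 (0.38 log units; beyond the scatter). Nothing available explains either step. The compounds shown leave open whether a methyl group or bromine could stand in place of the chlorine. They also leave open whether an amide could replace the carboxylic acid on this ring.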